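Trimming a Side Chain on a Weak Caspase-8 Inhibitor

A few compounds are considered here, and "the series" means these few. Any claim that something is new, unique, unknown or untested is made for them only; others in the source may bear on it.

Compound 1 `CCC(C(=O)N[C@@H](CC(=O)O)C(=O)CSCc1ccccc1)n1ccnc(NCC2COc3ccccc3O2)c1=O` was tested in an assay for inhibition of Caspase-8 (Homo sapiens) (on this read-out lower numbers stand for stronger inhibition and higher numbers for weaker inhibition), where compound 1 gives 8220 nM. Compound 2 `CCC(C(=O)N[C@@H](CC(=O)O)C(=O)CNCN1CCCCC1)n1cc(C(C)(C)C)nc(NCc2nonc2C)c1=O` returns only a limit in this assay, > 10000 nM, so its true value is not known. Of the two numbers shown, compound 2 sits at the limit of > 10000 nM in this assay, at which 1 of the 2 values shown sits. Compound 3 `CCC(C(=O)N[C@@H](CC(=O)O)C(C)=O)n1cc(C(C)(C)C)nc(NCc2nonc2C)c1=O` differs from compound 2 by hydrogen in place of ((piperidin-1-yl)methyl)amino on a saturated chain carbon bound to a carbonyl carbon. With compound 2 already at the limit, the step from compound 2 to compound 3 has no measured neighbour to lean on, and no direction beyond the scatter is expected. Compound 3 is therefore expected to stay weak, near 15000 nM with a range of 5000 nM to 50000 nM, which would mean an expected step that the limit leaves unreadable from compound 2 to compound 3.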

Compound 3, half-maximal inhibitory concentration: 10000 nM
Compound 3: middle estimate off by 1.5-fold (0.18 log units), on the high side; measured number inside the range.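

In this assay, compound 3 gives a true number, 10000 nM, even though the whole ((piperidin-1-yl)methyl)amino group has gone, so this side chain is not needed for a measurable read-out. Hydrogen in place of this group gives a number no higher from compound 2 to compound 3 (the limit leaves the size open). Compound 2 gives only a limit, > 10000 nM. The size of the change on this saturated chain carbon bound to a carbonyl carbon therefore cannot be read, and that gap traces to one value: the limit of > 10000 nM in this assay, at which 1 of the 3 values shown sits.

Still open, on these data alone, is whether a small group on this carbon, such as a primary amine or a methoxy group, would give a lower number than compound 3.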